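The compounds below may be only part of what the source reports. "The series", "measured", "known", "first", "only" and "open" are said of these compounds alone.

Measured in a physicochemical assay for lipophilicity, using the shake flask method, in phosphate buffer, measured as octanol-water partition, with a stated time of 24 h, at pH 7.4, tested at 100 uM; a higher number here means a more lipophilic compound, a lower number a more polar compound:
- compound 1 `Cc1cc(O)cc(C)c1-c1cccc(COc2ccc(OCC(=O)O)c(F)c2)c1`: 2.37
- compound 2 `Cc1cc(OCC(=O)N(C)C)cc(C)c1-c1cccc(COc2ccc(OCC(=O)O)c(F)c2)c1`: "not determined" (no result reported)
- compound 3 `CCCOc1cc(C)c(-c2cccc(COc3ccc(OCC(=O)O)c(F)c3)c2)c(C)c1`: 3.64

Compound 3, at 3.64, holds the higher of the two numbers available, and compound 2 adds no number to compare. The next compound, compound 4 `COCCOc1cc(C)c(-c2cccc(COc3ccc(OCC(=O)O)c(F)c3)c2)c(C)c1`, turns the propoxy of compound 3 into 2-methoxyethoxy: methoxy in place of methyl on a saturated chain carbon, two bonds along the chain from an oxygen on an aromatic ring. Among the compounds with values here, only one measured step bears on this change, a number 1.27 log units higher from compound 1 to compound 3 (beyond the scatter), a large step beyond the scatter in which propyl takes the place of hydrogen on an oxygen on an aromatic ring. Within the data shown here, that step installs the chain that compound 4 then alters, but it does not measure the exchange of methyl for methoxy, and no measured pair does. The expectation is therefore an extrapolation: a moderate step downward in this assay, smaller than the step that separates the two measured compounds. The estimated step is a number 0.74 log units lower from compound 3 to compound 4 (beyond the scatter). For compound 4 the expected value is 2.9, with an estimated range of 2.5 to 3.3.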

Compound 4, distribution coefficient: 3.15
Compound 4: the middle estimate sits 0.25 log units below what was measured; the measured number falls inside the stated range.
By their numbers in this assay, from the lowest: compound 1; then compound 4; then compound 3.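

In this assay, within the data shown here, the exchange at the far end of the chain now has a measured size: methoxy in place of methyl gives a number 0.49 log units lower from compound 3 to compound 4 (beyond the scatter), a reading that the earlier compounds did not provide. Measured against the free hydrogen, the 2-methoxyethyl chain still gives a number 0.78 log units higher from compound 1 to compound 4 (beyond the scatter), so methoxy takes back only part of the rise that came with propyl. Nothing at hand accounts for the size or direction of this shift.

The compounds shown leave open where a chain ending in an amine or a carboxylic acid, or a longer chain carrying the same methoxy, would fall in this assay. Compound 2, with no result reported, gives no number for placing its chain among the others.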